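Dithiol Anilides: One Chloro Step Seen Twice

A few compounds are considered here, and "the series" means these few. Any claim that something is new, unique, unknown or untested is made for them only; others in the source may bear on it.

Compound 1, `O=C(CCCCC(S)CCS)Nc1ccccc1`, gives 9.49% in a functional assay on KB cells (Homo sapiens) for inhibition, read by MTT assay, with a stated time of 24 h, tested at 0.1 ug/mL; a higher number here means more inhibition of growth at the concentration tested, a lower number less inhibition of growth.
Compound 2, `O=C(CCCCC(S)CCS)Nc1ccc(Cl)cc1`, gives 9.11% in this assay.
Compound 3, `O=C(CCCCC(S)CCS)Nc1ccccn1`, is reported as "not active" (no number reported) in this assay, with no single number.

The change from compound 1 to compound 2 is chloro in place of hydrogen on an aromatic carbon, and its step is a number 0.4 percentage points lower from compound 1 to compound 2 (within the scatter). The two cores differ by pyridin-2-yl in place of phenyl on an amide-type nitrogen. Compound 4, `O=C(CCCCC(S)CCS)Nc1ccc(Cl)cn1`, differs from compound 3 by chloro in place of hydrogen on an aromatic carbon; this is the same kind of change, though here the place is on a six-membered aromatic ring with 1 nitrogen, two atoms from the ring nitrogen, rather than a ring of carbon only. In this assay a similarly small step from compound 3 to compound 4 is expected, resting on the step of a number 0.4 percentage points lower from compound 1 to compound 2 (within the scatter), while compound 3 itself gives no number to build on. Compound 4 is therefore estimated at 5% in this assay, between 0% and 14%.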

Compound 4, percent growth inhibition at one concentration: "not active" (no number reported)
Compound 4: no number reported, and the estimate cannot be compared.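

In this assay compound 3 and compound 4 both lack a number, so no new step can be read, and no other measurement shown bears on this result. The compounds shown leave open whether chloro in place of hydrogen changes growth inhibition on this nitrogen-containing ring.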